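A Halogen Swap and the Cytotoxicity Limit

This account rests on a few compounds, and the source may have more. Where it says the series, first, only, none or still open, it means among the compounds named here.

Three compounds of one series were tested in an ADME assay on HepG2 cells (Homo sapiens) for cytotoxicity, with a stated time of 72 h; on this read-out higher numbers stand for an effect only at larger amounts of compound and lower numbers for an effect already at smaller amounts. Compound 1, `Cc1cc(NC(=O)c2cc([N+](=O)[O-])ccc2Cl)cc(-c2nc3ccccc3s2)c1O`, gives > 25000 nM, which is a limit of the assay rather than a number. Compound 2, `O=C(Nc1nc(-c2ccc(Cl)cc2)cs1)c1cc([N+](=O)[O-])ccc1Cl`, gives > 27000 nM, again a limit. Compound 3, `Cc1ccc(-c2nc3ccccc3o2)cc1NC(=O)c1cc([N+](=O)[O-])ccc1Cl`, gives > 14000 nM, also a limit. Compound 2 therefore stands where the other two stand: no cytotoxic effect appeared up to the highest amount tested, and the three limits (the limit of > 14000 nM in this assay, at which 1 of the 3 values shown sits), the limit of > 25000 nM in this assay, at which 1 of the 3 values shown sits, and the limit of > 27000 nM in this assay, at which 1 of the 3 values shown sits, differ only in how far each run reached.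

Compound 4, `O=C(Nc1nc(-c2ccc(F)c(F)c2)cs1)c1cc([N+](=O)[O-])ccc1Cl`, has not yet been measured in this assay. It differs from compound 2 in one place: 3,4-difluorophenyl in place of 4-chlorophenyl on an aromatic carbon. Going by the values given here, no measured pair that differs in a single place is available, so the size of this kind of step cannot be read from data. Because compound 2 stands at the limit of > 27000 nM in this assay, at which 1 of the 3 values shown sits, while the rest of the structure is kept, the step of a number no higher from compound 2 to compound 4 (the limit leaves the size open) is expected to be nothing beyond the scatter. Compound 4 is expected to give 27000 nM, within 10000 nM to 60000 nM, most likely reported once more as a limit.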

Compound 4, half-maximal effective concentration: > 27000 nM
Compound 4: a limit, no number (the forecaster's own chance of this, stated with the estimate: 85%); the middle value lies on the limit itself.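

Compound 2 and compound 4 both end at a limit of the assay rather than a number, so the swap of 4-chlorophenyl for 3,4-difluorophenyl gives no step that can be read: the limit of > 27000 nM in this assay, at which 2 of the 4 values shown sit.

The compounds shown leave open at what amount, if any, each would become toxic to these cells.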